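A few compounds are considered here, and "the series" means these few. Any claim that something is new, unique, unknown or untested is made for them only; others in the source may bear on it.

Measured so far:
- Compound 1, `COc1ccccc1/C=C1\CCC/C(=C\c2cccc(OC)c2OC)C1=O`: 12000 nM
- Compound 2, `COc1cccc(/C=C2\CCC/C(=C\c3cc(OC)c(OC)c(OC)c3)C2=O)c1OC`: 1400 nM

Both compounds were tested in a functional assay on MCF7 cells (Homo sapiens) for cytotoxicity, read by MTT assay, with a stated time of 72 h; on this read-out higher numbers stand for weaker inhibition and lower numbers for stronger inhibition. Compound 1 stands with the highest of the two numbers, at 12000 nM. Among the measured compounds shown here, its nearest neighbour, compound 2, gives 1400 nM, a number that sits well beyond the usual scatter from that of compound 1, so the two values show a real difference between them, though no single-point step links the two structures.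

The next compound, compound 3, `COc1cccc(/C=C2\CCC/C(=C\c3ccc(O)c(Cl)c3)C2=O)c1OC`, is not yet measured. It differs from compound 1 in one place: 3-chloro-4-hydroxyphenyl in place of 2-methoxyphenyl on a double-bonded chain carbon bound to a double-bonded ring carbon. The arm that carries 2-methoxyphenyl in compound 1 is thus exchanged for 3-chloro-4-hydroxyphenyl, while the rest of the shared core stays as it is.

Since compound 2 shows that a different aryl group on this arm can go with a lower number in this assay, compound 3 is expected to move in the same direction, towards stronger inhibition, and the step of a 3.0-fold lower number from compound 1 to compound 3 (0.48 log units; beyond the scatter) is estimated to lie beyond the scatter. The value expected for compound 3 is 4000 nM, within a range from 1000 nM to 15000 nM.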

Compound 3, half-maximal inhibitory concentration: 16400 nM
The estimate for compound 3 lay 4.1-fold (0.61 log units) below the measured number, outside the stated range (above it).
By their numbers in this assay, from the lowest: compound 2; then compounds 1 and 3 (each within the scatter of the next).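

In this assay, among the compounds shown here, placing 3-chloro-4-hydroxyphenyl in place of 2-methoxyphenyl on a double-bonded chain carbon bound to a double-bonded ring carbon gives a 1.4-fold higher number from compound 1 to compound 3 (0.14 log units; within the scatter) and so provides the first one-place step at this position. Exchanging the aryl group on this arm therefore does not by itself bring a lower number, and the entry of a chlorine atom and a hydrogen-bond donor, with the loss of the methoxy group, leaves no difference that can be told from the scatter in this pair. Nothing at hand bears on why the two numbers stay so close.

The chlorine and the hydroxyl enter together, so the compounds shown leave open what either would do alone, and whether the two separately would also stay within the scatter of compound 1 or instead part from it. They also leave open how this arm responds to a group of another kind, such as a phenyl ring carrying an amine or a carboxylic acid, or a longer chain in place of the aryl group.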